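Compound 3: A Triazole on the Carbamate Nitrogen

This account rests on a few compounds, and the source may have more. Where it says the series, first, only, none or still open, it means among the compounds named here.

Compound 1 `C=C1C(=O)O[C@H]2[C@H]1CC/C(COC(=O)N1CCC(F)(F)CC1)=C\CC[C@@]1(C)O[C@@H]21`: 1900 nM
Compound 2 `C=C1C(=O)O[C@H]2[C@H]1CC/C(COC(=O)NCCN1CCCC1)=C\CC[C@@]1(C)O[C@@H]21`: 4180 nM

Within the data shown here, in a functional assay on Malme-3M cells (Homo sapiens) for inhibition (a higher number here means a weaker inhibitor of growth, a lower number a stronger inhibitor of growth), compound 2 gives 4180 nM, the higher of the two numbers measured so far, which makes it the weaker growth inhibitor of the pair. The next compound to be tested is compound 3 `C=C1C(=O)O[C@H]2[C@H]1CC/C(COC(=O)Nc1n[nH]c(SC)n1)=C\CC[C@@]1(C)O[C@@H]21`, which has not yet been measured. Its structure departs from compound 2 in one place: 5-(methylsulfanyl)-1H-1,2,4-triazol-3-yl in place of 2-(pyrrolidin-1-yl)ethyl on an amide-type nitrogen. In words, 5-(methylsulfanyl)-1H-1,2,4-triazol-3-yl stands in place of 2-(pyrrolidin-1-yl)ethyl on an amide-type nitrogen, and the rest of the molecule stays the same.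

Among the measured compounds shown here, only one measured step touches this part of the molecule, and it was modest: a 2.2-fold higher number from compound 1 to compound 2 (0.34 log units; beyond the scatter). Neither measured compound carries the incoming group, so this step is a loose guide at best. Going by that single step, only a small move is expected in this assay, towards a lower number, and it may not exceed the scatter. The expected change is a 1.5-fold lower number from compound 2 to compound 3 (0.17 log units; within the scatter). For compound 3 the estimated value is 2800 nM, with an expected range of 800 nM to 9000 nM.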

Compound 3, concentration for 50% growth inhibition: 2320 nM
The estimate for compound 3 lay 1.2-fold (0.08 log units) above the measured number, within the range that was stated.
By their numbers in this assay, from the lowest: compounds 1, 3 and 2 (each within the scatter of the next, the first and the last beyond it).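

In this assay, placing 5-(methylsulfanyl)-1H-1,2,4-triazol-3-yl on the amide-type nitrogen instead of 2-(pyrrolidin-1-yl)ethyl gives a 1.8-fold lower number from compound 2 to compound 3 (0.26 log units; within the scatter) and so does not separate the two compounds, although an aromatic ring with three hetero atoms has replaced a non-aromatic ring with one. Setting (5-(methylsulfanyl)-1H-1,2,4-triazol-3-yl)amino on the carbonyl carbon in place of 4,4-difluoropiperidin-1-yl gives a 1.2-fold higher number from compound 1 to compound 3 (0.09 log units; within the scatter) and does not separate those two compounds either, so compound 3 lies within the scatter of both compound 1 and compound 2, even though those two lie beyond the scatter of each other. No independent measurement is available to explain this result.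

On these data alone, it remains open whether the methylsulfanyl group matters, which a comparison with the same triazole carrying only hydrogen in its place could show. As far as these compounds go, it is also open whether a carboxylic acid or a plain phenyl ring on the amide-type nitrogen would move the number beyond the scatter in this assay and show how much this position can accept.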